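The source may report more compounds than this note shows. Statements on the series, on what has been measured and on what is new or still open speak of the compounds shown alone.

Working notes on a set of four compounds built on one core, taken pairwise. Compound 1 `Nc1ncnc2c1ccn2-c1ccc(NC(=O)Nc2ccc(Cl)c(Cl)c2)cc1` and compound 2 `O=C(Nc1ccc(-n2ccc3c(NC(=O)c4ccccc4)ncnc32)cc1)Nc1ccc(Cl)c(Cl)c1` form the first pair; compound 3 `Nc1ncnc2c1ccn2-c1ccc(NC(=O)c2cccc(C(F)(F)F)c2)cc1` and compound 4 `O=C(Nc1ccc(-n2ccc3c(NC(=O)c4ccccc4)ncnc32)cc1)c1cccc(C(F)(F)F)c1` form the second. Within each pair the change is the same: benzoyl in place of hydrogen on a nitrogen on an aromatic ring in the first pair and benzoyl in place of hydrogen on a nitrogen on an aromatic ring in the second, made at the same place, on a nitrogen on an aromatic ring whose other neighbours are aromatic carbon. The difference between the core of compound 1 and the core of compound 3 is not broken down here.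

In a functional assay on A375P cells (Homo sapiens) for antiproliferative activity, read by MTT assay, with a stated time of 24 h (a lower number here means a stronger inhibitor, a higher number a weaker inhibitor), compound 1 gives 5400 nM, and compound 2 gives 4000 nM. The first pair therefore shows a 1.4-fold lower number from compound 1 to compound 2 (0.13 log units; within the scatter). Compound 3 gives 9700 nM in this assay, which is the highest of the three numbers; it sits within the scatter of compound 1 but beyond the scatter from compound 2.

Compound 4 is not yet measured. Because a 1.4-fold lower number from compound 1 to compound 2 (0.13 log units; within the scatter) lies within the scatter, the step from compound 3 to compound 4 is estimated at a 1.4-fold lower number from compound 3 to compound 4 (0.14 log units; within the scatter), a small move in the same direction, with the caveat that a single precedent carries little weight and the two cores differ in a way not broken down here. In this assay compound 4 is expected to give 7000 nM, with a likely range from 3000 nM to 16000 nM.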

Compound 4, half-maximal inhibitory concentration: 4700 nM
The estimate for compound 4 lay 1.5-fold (0.17 log units) above the measured number, within the range that was stated.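

In this assay, benzoyl in place of hydrogen on the nitrogen gives a 2.1-fold lower number from compound 3 to compound 4 (0.31 log units; beyond the scatter), and set beside the first pair, the two steps do not differ: the same change on two cores in this assay, a 1.4-fold lower number (0.13 log units; within the scatter) from compound 1 to compound 2 and a 2.1-fold lower number (0.31 log units; beyond the scatter) from compound 3 to compound 4, 1.5-fold (0.18 log units) apart, within the scatter of two such steps. Within the data shown here, the change therefore carries across these two cores with a similar size, but only the step on the second pair stands clear of the scatter, so the pairs do not establish a reliable gain from benzoyl, and two cores cannot show that the result would hold on a third or explain it. With benzoyl in place on both compounds, the exchange on the carbonyl carbon gives a 1.2-fold higher number from compound 2 to compound 4 (0.07 log units; within the scatter), so this comparison does not separate 3-(trifluoromethyl)phenyl from (3,4-dichlorophenyl)amino.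

The compounds shown leave open whether the step depends on benzoyl itself or would also appear with a smaller acyl group such as acetyl, a longer alkyl chain, or a benzoyl ring carrying a carboxylic acid or an amine. They also leave open whether the same step would appear in any read-out other than this assay, since all four compounds are compared in this one only.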